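This account rests on a few compounds, and the source may have more. Where it says the series, first, only, none or still open, it means among the compounds named here.

Compound 1 `O=C(CCCCCCc1ccccc1)c1ncc(-c2ccccc2F)o1` gives 110 nM. Compound 2 `NC(=O)c1cccc(-c2cnc(C(=O)CCCCCCc3ccccc3)o2)c1` gives 6 nM. Compound 3 `O=C(CCCCCCc1ccccc1)c1ncc(-c2ccc([N+](=O)[O-])cc2)o1` gives 50 nM.

In an assay (Rattus norvegicus) for inhibition of Fatty-acid amide hydrolase 1 (Homo sapiens) (on this read-out lower numbers stand for stronger inhibition and higher numbers for weaker inhibition), compound 3 sits second highest of the three, close to compound 1 and well apart from compound 2. Compound 4 `Nc1ccc(-c2cnc(C(=O)CCCCCCc3ccccc3)o2)cc1` differs from compound 3 in one place: amino in place of nitro on an aromatic carbon. Among the measured compounds shown here, no measured step swaps nitro for amino; the steps that bear on it change the group on the same aromatic carbon. Those steps run a 2.2-fold lower number from compound 1 to compound 3 (0.34 log units; beyond the scatter), an 18-fold lower number from compound 1 to compound 2 (1.26 log units; beyond the scatter) and an 8.3-fold higher number from compound 2 to compound 3 (0.92 log units; beyond the scatter), so this position tolerates change and can reward it. A group with a hydrogen-bond donor, as in compound 2, went with the lowest number. For compound 4 a modest lower number is therefore expected, a 1.4-fold lower number from compound 3 to compound 4 (0.15 log units; within the scatter), with an estimate of 35 nM (range 10 nM to 150 nM).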

Compound 4, inhibition constant: 90 nM
The estimate for compound 4 lay 2.6-fold (0.41 log units) below the measured number, within the range that was stated.
By their numbers in this assay, from the lowest: compound 2; then compounds 3, 4 and 1 (each within the scatter of the next, the first and the last beyond it).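

Amino brings a hydrogen-bond donor in place of nitro, yet the change gives a 1.8-fold higher number from compound 3 to compound 4 (0.26 log units; within the scatter) and leaves compound 4 with a 1.2-fold lower number from compound 1 to compound 4 (0.09 log units; within the scatter) as well. The gap to the best compound remains, with a 15-fold higher number from compound 2 to compound 4 (1.18 log units; beyond the scatter), so compound 4 goes against the idea that any donor on this ring gives a low number. No measurement shown here explains this result.

Still open, going by these compounds, is whether the low number of compound 2 goes with the carbamoyl group itself or with its place on the ring. A carboxylic acid or a nitrile on the same carbon would help to separate the two.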